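Changing one aryl group on an inactive core

The source may hold more compounds than are shown below. What is called first, only, known or untested is meant among the compounds shown, and "the series" means these compounds.

Compound 1 `C=CCn1c(=O)/c(=C\c2ccc(Cl)c(Cl)c2)[nH]c(=O)/c1=C\c1ccccc1OC` was tested in a functional assay on HeLa cells (Homo sapiens) for cytotoxicity, read by CCK-8 assay, with a stated time of 72 h (on this read-out lower numbers stand for stronger inhibition and higher numbers for weaker inhibition), and gives "not active" (no number reported), so no number stands for it. Compound 3 `C=CCn1c(=O)/c(=C\c2ccc(Cl)c(Cl)c2)[nH]c(=O)/c1=C\c1ccccc1`, which carries the same allyl group and the same 3,4-dichlorophenyl, likewise gives "not active" (no number reported) in this assay. Compound 2 `COc1ccccc1/C=c1\c(=O)[nH]/c(=C/c2cccc(Cl)c2Cl)c(=O)n1C`, with a methyl group on the ring nitrogen and a 2,3-dichlorophenyl, gives 200 nM in this assay, the only numerical result among the three measured compounds. Compound 4 `C=CCn1c(=O)/c(=C\c2cc(F)ccc2C)[nH]c(=O)/c1=C\c1ccccc1OC` has not been measured. The change from compound 1 is 5-fluoro-2-methylphenyl in place of 3,4-dichlorophenyl on a double-bonded chain carbon bound to an aromatic carbon; the allyl group and the methoxyphenyl group of compound 1 are kept. Among the compounds with values here, no step between two measured compounds covers this exchange, so the direction of any change is open. Because compound 1 gives "not active" (no number reported) and compound 3 gives "not active" (no number reported), both with the allyl group that compound 4 also carries, compound 4 is expected to remain weak. Compound 4 is expected to give 20000 nM in this assay, with a range from 2000 nM to 100000 nM.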

Compound 4, half-maximal inhibitory concentration: 2900 nM
Beside the measured number, compound 4's estimate is 6.9-fold (0.84 log units) above it; the measured number falls inside the stated range.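

No step can be read between compound 1 and compound 4, since compound 1 has no number to set against the result for compound 4. The compounds shown leave open how far exchanging 3,4-dichlorophenyl for 5-fluoro-2-methylphenyl alone shifts cytotoxicity. No measurement shown explains the result.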